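A few compounds are considered here, and "the series" means these few. Any claim that something is new, unique, unknown or untested is made for them only; others in the source may bear on it.

Measured in a functional assay on OVCAR cells (Homo sapiens) for cytotoxicity, read by sulforhodamine B assay, with a stated time of 48 h; on this read-out higher numbers stand for weaker inhibition and lower numbers for stronger inhibition:
- compound 1 `O=CCN1N=C(c2ccc3ccccc3c2)CC1c1ccccc1[N+](=O)[O-]` gives 3480 nM
- compound 2 `O=CCN1N=C(c2ccc3ccccc3c2)CC1c1cccc(Cl)c1Cl` gives 15100 nM

Among the measured compounds shown here, of these two numbers, the higher belongs to compound 2, at 15100 nM, and compound 1 is its only neighbour. The next compound, compound 3 `O=CCN1N=C(c2ccc3ccccc3c2)CC1c1ccco1`, carries furan-2-yl in place of 2,3-dichlorophenyl on a saturated ring carbon.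

For the measured compounds named here, one measured step bears on this change, as it touches the same ring carbon. It is a 4.3-fold higher number from compound 1 to compound 2 (0.64 log units; beyond the scatter), a modest move that lies beyond the scatter. That step brought in the 2,3-dichlorophenyl group that now leaves, and the number rose with it. Going by the values given here, no measured compound carries furan-2-yl, so the direction rests on this single step. A modest step towards a lower number in this assay therefore seems more likely than none, and a move within the scatter cannot be ruled out.

The expected change is a 2.2-fold lower number from compound 2 to compound 3 (0.33 log units; beyond the scatter). For compound 3 the estimated value is 7000 nM, with an expected range of 2000 nM to 22000 nM.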

Compound 3, half-maximal inhibitory concentration: 18000 nM
Estimate against measurement, compound 3: 2.6-fold (0.41 log units) below; low and high end bracket the measured number.
By their numbers in this assay, from the lowest: compound 1; then compounds 2 and 3 (each within the scatter of the next).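

In this assay, the change gives a 1.2-fold higher number from compound 2 to compound 3 (0.08 log units; within the scatter), so the smaller furan-2-yl, which adds a hydrogen-bond acceptor, and the larger 2,3-dichlorophenyl group cannot be told apart on this saturated ring carbon. The other comparison gives a 5.2-fold higher number from compound 1 to compound 3 (0.71 log units; beyond the scatter), which places the 2-nitrophenyl compound apart from the furan-2-yl compound as well as from the 2,3-dichlorophenyl compound. Among the compounds shown here, the earlier pair could show only that two groups differed, whereas these three compounds show two unlike rings sharing one level, with compound 1 alone giving a lower number.

Nothing available here explains why compound 1 stands apart from the other two. The compounds shown leave open whether the nitro group itself goes with the lower number, which a plain phenyl, an aminophenyl or a cyanophenyl group on the same ring carbon could help to settle, and whether any group can take the number lower than 2-nitrophenyl does.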